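Compound 2 to compound 3: a 4-ethylphenyl swap

This account rests on a few compounds, and the source may have more. Where it says the series, first, only, none or still open, it means among the compounds named here.

Among the compounds with values here, in a functional assay on HT-29 cells (Homo sapiens) for inhibition, read by sulforhodamine B assay, with a stated time of 48 h (on this read-out higher numbers stand for weaker inhibition of growth and lower numbers for stronger inhibition of growth), compound 1 (`Cc1ccc(C2=NN(c3ccc(S(C)(=O)=O)cc3)C(=O)CC2)cc1`) gives 330 nM and compound 2 (`Cc1cc(O)ccc1C1=NN(c2ccc(S(C)(=O)=O)cc2)C(=O)CC1`) gives 3700 nM as the higher of the two numbers so far. The move to compound 3 (`CCc1ccc(C2=NN(c3ccc(S(C)(=O)=O)cc3)C(=O)CC2)cc1`) is 4-ethylphenyl in place of 4-hydroxy-2-methylphenyl on a carbon with a double bond to nitrogen on the shared core. Within the data shown here, the one measured step bearing on this, an 11-fold higher number from compound 1 to compound 2 (1.05 log units; beyond the scatter) and large, brought in the 4-hydroxy-2-methylphenyl group that leaves here. A large step to a lower number in this assay is therefore expected, estimated as a 7.4-fold lower number from compound 2 to compound 3 (0.87 log units; beyond the scatter) in size. The estimate for compound 3 is 500 nM with an expected range of 150 nM to 1700 nM around it.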

Compound 3, concentration for 50% growth inhibition: 410 nM
For compound 3 the middle estimate is 1.2-fold (0.09 log units) above the measured one, and the stated range covers the measured number.
By their numbers in this assay, from the lowest: compounds 1 and 3 (each within the scatter of the next); then compound 2.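

In this assay the group swap gives a 9.0-fold lower number from compound 2 to compound 3 (0.96 log units; beyond the scatter), so a 4-ethylphenyl group at this position does not carry the penalty seen with 4-hydroxy-2-methylphenyl. The extra methyl on the saturated chain carbon gives a 1.2-fold higher number from compound 1 to compound 3 (0.09 log units; within the scatter), so this one-carbon extension leaves the read-out unresolved from that of compound 1. No data on hand account for the difference between these groups.

The compounds shown do not separate the hydroxy group from the ring methyl within 4-hydroxy-2-methylphenyl. From the compounds shown here alone, how a propyl chain or an amine in place of the ethyl would read remains open.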